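Removing the nitro group from compound 3

The source may hold more compounds than are shown below. What is called first, only, known or untested is meant among the compounds shown, and "the series" means these compounds.

Values in a functional assay on ASPC1 cells (Homo sapiens) for cytotoxicity; a lower number here means a stronger inhibitor, a higher number a weaker inhibitor:
Compound 1 `COc1ccc2nc(NC(=O)CCCCC(=O)NO)sc2c1`: 23.9 ug/mL
Compound 2 `Cc1ccc2nc(NC(=O)CCCCC(=O)NO)sc2c1`: 13.3 ug/mL
Compound 3 `O=C(CCCCC(=O)Nc1nc2ccc([N+](=O)[O-])cc2s1)NO`: > 30 ug/mL
Compound 4 `O=C(CCCCC(=O)Nc1nc2ccccc2s1)NO`: not yet measured

For compound 3, > 30 ug/mL is a limit of the assay and not a number. Compound 4 differs from it by one change, hydrogen in place of nitro on an aromatic carbon.

Among the measured compounds shown here, three measured steps bear on this. Nitro in place of methyl gave an at least 2.2-fold higher number from compound 2 to compound 3 (0.35 log units; beyond the scatter), and nitro in place of methoxy gave an at least 1.2-fold higher number from compound 1 to compound 3 (0.09 log units; that floor lies within the scatter). Methyl in place of methoxy gave a 1.8-fold lower number from compound 1 to compound 2 (0.25 log units; within the scatter). For the measured compounds named here, only the step to compound 3 from compound 2 clearly exceeds the scatter, and it points to nitro raising the number. Losing the nitro is therefore expected to lower the number in this assay, though the limit on compound 3 leaves the true size open. The expected step is an at least 1.8-fold lower number from compound 3 to compound 4 (0.27 log units; that floor lies within the scatter). The expectation rests on compound 2 at 13.3 ug/mL and compound 1 at 23.9 ug/mL, which lie within the scatter of each other. Compound 4 is estimated at 16 ug/mL, with an expected range from 7 ug/mL to 30 ug/mL.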

Compound 4, half-maximal inhibitory concentration: 10.2 ug/mL
Beside the measured number, compound 4's estimate is 1.6-fold (0.20 log units) above it, within the range that was stated.
By their numbers in this assay, from the lowest: compounds 4, 2 and 1 (each within the scatter of the next, the first and the last beyond it). At a limit, above all of these: compound 3.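

In this assay, replacing the nitro on this aromatic carbon with hydrogen gave an at least 2.9-fold lower number from compound 3 to compound 4 (0.46 log units; beyond the scatter), so the bare parent now shows a clear penalty for nitro, a comparison that previously rested on methyl alone. Hydrogen and methyl cannot be told apart here, with a 1.3-fold lower number from compound 2 to compound 4 (0.12 log units; within the scatter), whereas hydrogen in place of methoxy gave a 2.3-fold lower number from compound 1 to compound 4 (0.37 log units; beyond the scatter), a separation that the earlier comparison of methyl with methoxy did not reach. Compound 3 stands at a limit of the assay, so the step from it gives only a floor: the limit of > 30 ug/mL in this assay, at which 1 of the 4 values shown sits.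

As far as these compounds go, the true size of the nitro penalty therefore remains open. Also open, from the compounds shown here alone, is whether an amine, a chlorine atom or a trifluoromethyl group on this carbon would sit with hydrogen and methyl or would raise the number as nitro does.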